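The compounds below may be only part of what the source reports. "The series", "measured", "known", "first", "only" and "open" are said of these compounds alone.

Working notes on the series. In a functional assay on KB cells (Homo sapiens) for cytotoxicity (on this read-out higher numbers stand for weaker inhibition and lower numbers for stronger inhibition), compound 1 (`CCOCn1cc(C#N)c2c(N)ncnc21`) gives > 100000 nM, and this is a limit of the assay, not a number. Compound 1 therefore has no exact position on the scale, as the limit of > 100000 nM in this assay, at which 1 of the 2 values shown sits, records. Compound 2 (`CC(C)(C)c1ccc(Cn2cc(C#N)c3c(N)ncnc32)cc1`) gives a measured number in this assay, 3000 nM. The next compound to be read is compound 3 (`Cn1cc(C#N)c2c(N)ncnc21`). Its change from compound 1 is hydrogen in place of ethoxy on a saturated chain carbon bound to an aromatic nitrogen, which turns ethoxymethyl to methyl. Within the data shown here, no measured step covers this change, so the expectation rests on compound 1 at > 100000 nM. No shift beyond the scatter is expected in this assay, and a second reading at the limit is likely. The expected size of the step of a number no higher from compound 1 to compound 3 (the limit leaves the size open) is small. For compound 3 the estimate is 100000 nM, with an expected range of 20000 nM to 200000 nM.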

Compound 3, half-maximal inhibitory concentration: > 100000 nM
Compound 3 was reported as a limit; the forecaster's own chance of this, stated with the estimate: 70%; the middle value sits exactly at the limit.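

Compound 1 and compound 3 are both limits of the assay in this assay, so no step can be read between them: the limit of > 100000 nM in this assay, at which 2 of the 3 values shown sit.

The compounds shown leave open whether hydrogen in place of ethoxy changes the cytotoxicity read-out at all, and how far apart compound 1 and compound 3 truly lie.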